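From Cyclobutylmethyl to Oxan-4-yl on the Amide-Type Nitrogen

This account rests on a few compounds, and the source may have more. Where it says the series, first, only, none or still open, it means among the compounds named here.

Of the compounds shown here, three sharing one core have been measured in a functional assay on Shh Light II cells (Mus musculus) for inhibition, read by a luciferase reporter; on this read-out lower numbers stand for stronger inhibition and higher numbers for weaker inhibition. Compound 1 `O=C(NC1CCNCC1)N1CCC(c2nc(-c3ccc4ccccc4n3)no2)CC1` gives 2500 nM, compound 2 `CC(=O)N1CCC(NC(=O)N2CCC(c3nc(-c4ccc5ccccc5n4)no3)CC2)CC1` gives 500 nM, and compound 3 `O=C(NCC1CCC1)N1CCC(c2nc(-c3ccc4ccccc4n3)no2)CC1` gives 410 nM, the lowest of the three numbers, although its gap to compound 2 lies within the scatter. Compound 4 `O=C(NC1CCOCC1)N1CCC(c2nc(-c3ccc4ccccc4n3)no2)CC1` differs from compound 3 in one place: oxan-4-yl in place of cyclobutylmethyl on an amide-type nitrogen. Going by the values given here, two measured steps touch this same nitrogen: a 6.1-fold lower number from compound 1 to compound 3 (0.79 log units; beyond the scatter) and a 1.2-fold lower number from compound 2 to compound 3 (0.09 log units; within the scatter). Oxan-4-yl, like the piperidin-4-yl of compound 1 and the 1-acetylpiperidin-4-yl of compound 2, is a ring joined directly to that nitrogen, and compound 2 sits close to compound 3. The step is therefore expected to be small, a 1.3-fold higher number from compound 3 to compound 4 (0.13 log units; within the scatter). Compound 4 is estimated at 550 nM, ranging from 250 nM to 1200 nM.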

Compound 4, half-maximal inhibitory concentration: 480 nM
For compound 4 the middle estimate is 1.1-fold (0.06 log units) above the measured one; the range from low to high includes it.
By their numbers in this assay, from the lowest: compounds 3, 4 and 2 (each within the scatter of the next); then compound 1.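

In this assay the change from cyclobutylmethyl to oxan-4-yl on the amide-type nitrogen is tolerated: there is a 1.2-fold higher number from compound 3 to compound 4 (0.07 log units; within the scatter) and a 1.0-fold lower number from compound 2 to compound 4 (0.02 log units; within the scatter) and both steps leave the three groups indistinguishable, even with the added ring oxygen. Only piperidin-4-yl stands apart, since replacing it with oxan-4-yl gives a 5.2-fold lower number from compound 1 to compound 4 (0.72 log units; beyond the scatter) and this matches the gain from acetylating compound 1. No evidence here explains these numbers. On these data alone, it remains open how a longer chain or a carboxylic acid on this nitrogen would behave.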